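This account rests on a few compounds, and the source may have more. Where it says the series, first, only, none or still open, it means among the compounds named here.

Compound 1 `O=C(NC1CCCCC1)Oc1cccc(-c2cc(C(=O)NC3CCCCC3)nn2-c2ccccc2)c1`: 288 nM
Compound 2 `NC(=O)c1cc(-c2ccc(OC(=O)NC3CCCCC3)cc2)n(-c2ccccc2)n1`: 71 nM
Compound 3 `CCOC(=O)c1cc(-c2ccc(OC(=O)NC3CCCCC3)cc2)nn1-c1ccc(Cl)cc1`: 586 nM

Of the compounds shown here, three have been tested in an assay on isolated protein for inhibition of Fatty-acid amide hydrolase 1 (Homo sapiens), read by fluorescence, with a stated time of 30 min; a higher number here means a weaker inhibitor, a lower number a stronger inhibitor. Compound 1 gives 288 nM and stands second highest of the three; compound 3 gives a higher number, 586 nM, and compound 2 a lower one, 71 nM, both gaps lying beyond the usual scatter. Compound 4 `O=C(NC1CCCCC1)Oc1cccc(-c2cc(CO)nn2-c2ccccc2)c1` is built from compound 1 by a single change: hydroxymethyl in place of cyclohexylcarbamoyl on an aromatic carbon. For the measured compounds named here, no measured pair shows this exact change, so the expectation rests on the other two compounds, where the smaller group on the shared core, as in compound 2, goes with the lower number. The step is therefore expected to lower the number modestly, a 1.4-fold lower number from compound 1 to compound 4 (0.16 log units; within the scatter), within or just beyond the scatter. Compound 4 is estimated at 200 nM, with a range from 60 nM to 700 nM.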

Compound 4, half-maximal inhibitory concentration: 462 nM
For compound 4 the middle estimate is 2.3-fold (0.36 log units) below the measured one, within the range that was stated.
By their numbers in this assay, from the lowest: compound 2; then compounds 1, 4 and 3 (each within the scatter of the next, the first and the last beyond it).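

In this assay, hydroxymethyl in place of cyclohexylcarbamoyl gives a 1.6-fold higher number from compound 1 to compound 4 (0.21 log units; within the scatter) and so removes the six-membered ring from this position without a change that can be told from the scatter. For the compounds shown here, this is the first direct test at this position, and it shows that the level of inhibition seen in compound 1 does not depend on the large group. No measurement at hand explains this result. On these data alone, whether an amine, a carboxylic acid or a longer chain on this aromatic carbon would shift the number beyond the scatter remains open.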